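The source may report more compounds than this note shows. Statements on the series, on what has been measured and on what is new or still open speak of the compounds shown alone.

Compound 1 `Cc1ncn(-c2ccc(C(=O)N[C@@H]3CCN(c4ncc(Cl)c5c(N)noc45)C3)c(Cl)c2)n1` and compound 2 `Cn1cc(-c2ccc(C(=O)N[C@@H]3CCN(c4ncc(Cl)c5c(N)noc45)C3)c(Cl)c2)ccc1=O` share one core and differ only in the ring attached to the chlorinated benzene. In an ADME assay on a cell-free system (plasma, Homo sapiens), using equilibrium dialysis, with a stated time of 4 h, tested at 10 uM (on this read-out higher numbers stand for a larger free fraction and lower numbers for a smaller free fraction), compound 1 gives 0.002 and compound 2 gives 0.004; the step of a 2.0-fold higher number from compound 1 to compound 2 (0.30 log units; within the scatter) separates them, so the two numbers cannot be told apart with confidence. Compound 3 `Cn1cc(-c2ccc(C(=O)N[C@@H]3CCN(c4ncc(Cl)c5c(N)noc45)C3)c(Cl)c2)cnc1=O` takes the next step from compound 2: a group of 8 heavy atoms (5 carbon, 2 nitrogen, 1 oxygen; one six-membered aromatic ring with 2 hetero atoms) in place of a group of 8 heavy atoms (6 carbon, 1 nitrogen, 1 oxygen; one six-membered aromatic ring with 1 hetero atom), on an aromatic carbon. Among the compounds with values here, this change is smaller than the one from compound 1 to compound 2, which itself stayed within the scatter, so no step beyond the scatter is expected in this assay here either. The estimate for compound 3 is therefore 0.005, with a range from 0.0025 to 0.01, meaning an expected step of a 1.3-fold higher number from compound 2 to compound 3 (0.10 log units; within the scatter) from compound 2 to compound 3.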

Compound 3, unbound fraction: 0.017
Compound 3: middle estimate off by 3.4-fold (0.53 log units), on the low side, outside the stated range (above it).
By their numbers in this assay, from the lowest: compounds 1 and 2 (each within the scatter of the next); then compound 3.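

In this assay, trading the six-membered aromatic ring with 1 hetero atom for the one with 2 hetero atoms gives a 4.3-fold higher number from compound 2 to compound 3 (0.63 log units; beyond the scatter), so at this place, para to a large group, swapping one ring carbon for a nitrogen moves the free fraction beyond the scatter. The larger exchange of a five-membered ring for a six-membered one stayed within the scatter, so among these compounds the size of the structural change does not match the size of the step. Set against the five-membered aromatic ring with 3 hetero atoms, the new ring gives an 8.5-fold higher number from compound 1 to compound 3 (0.93 log units; beyond the scatter), and nothing available here accounts for either step.

The compounds shown leave open whether the placement of the two ring nitrogens matters, since only one arrangement appears. They also leave open how the free fraction would respond to a quite different group on this aromatic carbon, such as a carboxylic acid or an amine.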